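Adding a Second Methoxy Group: What Changes?

The compounds below may be only part of what the source reports. "The series", "measured", "known", "first", "only" and "open" are said of these compounds alone.

Compound 1 `COc1cccc(CNC(=O)C(C)Oc2ccc(Cl)cc2Cl)c1`: > 100000 nM
Compound 2 `COc1ccccc1CNC(=O)C(C)Oc1ccc(Cl)cc1Cl`: "not determined" (no result reported)
Compound 3 `COc1ccc(CNC(=O)C(C)Oc2ccc(Cl)cc2Cl)cc1OC`: 36000 nM

All three share one core and differ only in how methoxy groups sit on the benzylic ring. In an ADME assay on CHO cells (Cricetulus griseus) for cytotoxicity, read by LDH release (on this read-out lower numbers stand for stronger inhibition and higher numbers for weaker inhibition), compound 1 gives only a limit of the assay, > 100000 nM. Compound 3, with methoxy in place of hydrogen on an aromatic carbon, gives 36000 nM in this assay. The step of an at least 2.7-fold lower number from compound 1 to compound 3 (0.44 log units; beyond the scatter) is stated as "at least" because of the limit of > 100000 nM in this assay, at which 1 of the 3 values shown sits. For compound 2 no result is reported in this assay, so "not determined" (no result reported) stands for it. The difference between the cores of compound 1 and compound 2 is not broken down here.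

Compound 4 `COc1ccc(CNC(=O)C(C)Oc2ccc(Cl)cc2Cl)c(OC)c1` arises from compound 2 by methoxy in place of hydrogen on an aromatic carbon. This is the same kind of change as from compound 1 to compound 3, not the same: in compound 3 the entering methoxy is ortho to a methoxy group, in compound 4 it is meta to a methoxy group. Going by the values given here, with compound 2 unmeasured, the expectation for compound 4 rests on compound 3, whose 36000 nM is the only number at hand. Compound 4 is expected to give about 40000 nM in this assay, roughly between 10000 nM and 150000 nM.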

Compound 4, half-maximal inhibitory concentration: > 100000 nM
Compound 4 gave a limit, no number (the forecaster's own chance of this, stated with the estimate: 35%); middle value at least 2.5-fold (0.39 log units) from the limit.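

Compound 4 gives > 100000 nM in this assay, which is a limit of the assay and not a number. Going by these compounds alone, with no result reported for compound 2, no step from compound 2 to compound 4 can be read. The compounds shown leave open how much a methoxy group entering at this place changes the read-out.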